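The source may hold more compounds than are shown below. What is called first, only, known or untested is meant among the compounds shown, and "the series" means these compounds.

Measured compounds:
Compound 1 `Nc1cc(N)c2nc(-c3ccccc3)c(Sc3ccc(F)cc3)nc2c1`: < 100000 nM
Compound 2 `COc1cc(CNc2nc3cc(N)cc(N)c3nc2-c2ccccc2)cc(OC)c1OC`: 5250 nM
Compound 3 `CCOC(=O)[C@H](CCC(=O)O)NC(=O)c1ccc(CNc2nc3cc(N)cc(N)c3nc2-c2ccccc2)cc1`: < 100000 nM

All three were tested in a functional assay on DU-145 cells (Homo sapiens) for inhibition, read by sulforhodamine B assay, with a stated time of 48 h; on this read-out lower numbers stand for stronger inhibition of growth and higher numbers for weaker inhibition of growth. For compound 1 the value < 100000 nM is a limit of this assay and not a number. For compound 3 the value < 100000 nM is likewise only a limit. Compound 2, which carries a benzylamino group on the shared core, gives a real number, 5250 nM. Compound 1 therefore stands at the edge of what this assay reports, (the limit of < 100000 nM in this assay, at which 2 of the 3 values shown sit), and its place relative to the others cannot be fixed more closely.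

Compound 4 `Nc1cc(N)c2nc(-c3ccccc3)c(NCc3ccc(F)cc3)nc2c1` has not yet been measured. It differs from compound 1 in one place: (4-fluorobenzyl)amino in place of (4-fluorophenyl)sulfanyl on an aromatic carbon. Among the measured compounds shown here, no pair of measured compounds differs in a single place, so no measured step guides the estimate. Compound 1, with its (4-fluorophenyl)sulfanyl group, gives only a limit. Because compound 2 with a benzylamino group gives 5250 nM, a shift toward stronger inhibition of growth is expected, with the step in this assay estimated as a step that the limit leaves unreadable from compound 1 to compound 4. Compound 4 is expected to give about 15000 nM, in a range from 3000 nM to 80000 nM.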

Compound 4, concentration for 50% growth inhibition: 1510 nM
Compound 4: the middle estimate sits 9.9-fold (1.00 log units) above what was measured; the measured number lies below the stated range.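

Among the compounds shown here, no step from compound 1 to compound 4 can be read, because compound 1 gives only a limit and not a number: the limit of < 100000 nM in this assay, at which 2 of the 4 values shown sit. The compounds shown leave open how far (4-fluorobenzyl)amino in place of (4-fluorophenyl)sulfanyl shifts growth inhibition on the shared core.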